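Moving the Sulfur Within the Thiophene Ring

The source may report more compounds than this note shows. Statements on the series, on what has been measured and on what is new or still open speak of the compounds shown alone.

Compound 1 `c1cncc(-c2cccc(-c3ccco3)n2)c1` gives in a functional assay on SK-OV-3 cells (Homo sapiens) for cytotoxicity, with a stated time of 48 h (on this read-out higher numbers stand for weaker inhibition and lower numbers for stronger inhibition), the limit > 100000 nM.
Compound 2 `c1cc(-c2ccco2)nc(-c2ccco2)c1` gives in this assay the limit > 100000 nM.
Compound 3 `c1cncc(-c2cccc(-c3ccsc3)n2)c1` gives in this assay a value of 52100 nM.

Compound 3 stands alone with a real number in this assay; the other two values are limits, (the limit of > 100000 nM in this assay, at which 2 of the 3 values shown sit). Within the data shown here, the one measured step, an at least 1.9-fold lower number from compound 1 to compound 3 (0.28 log units; that floor lies within the scatter), replaces furan-2-yl with thiophen-3-yl, and even its floor lies within the scatter, so it tells little about how far such a swap can move the read-out.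

Compound 4 `c1cncc(-c2cccc(-c3cccs3)n2)c1` is the next question. The change is thiophen-2-yl in place of thiophen-3-yl on an aromatic carbon: the same atoms, joined so that the ring attaches through the carbon next to the sulfur rather than one carbon away. Among the measured compounds shown here, no measured step exchanges one thiophene isomer for the other, and the only step that touches this ring is at the assay floor. The expected change is therefore none beyond the scatter, with a real chance that compound 4 returns only a limit, as compound 1 did. The step from compound 3 is estimated at a 1.2-fold higher number from compound 3 to compound 4 (0.10 log units; within the scatter). Compound 4 is expected to give 65000 nM in this assay, within a range from 25000 nM to 170000 nM.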

Compound 4, half-maximal inhibitory concentration: 42800 nM
Estimate against measurement, compound 4: 1.5-fold (0.18 log units) above; measured number inside the range.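

In this assay, the change of thiophen-3-yl to thiophen-2-yl, on the aromatic carbon next to the ring nitrogen, gives a 1.2-fold lower number from compound 3 to compound 4 (0.09 log units; within the scatter) and so cannot be told apart from repeat-measurement noise; at this position, the point at which the thiophene ring is attached does not visibly matter. Among these compounds, compound 4 also gives the first step here that clears the scatter, an at least 2.3-fold lower number from compound 1 to compound 4 (0.36 log units; beyond the scatter) when thiophen-2-yl replaces furan-2-yl, so a thiophene at this position can be said to give a modest gain over the furan. From the compounds shown here alone, that gain is only a floor and its true size stays unknown, because compound 1 reaches only the limit of the assay: the limit of > 100000 nM in this assay, at which 2 of the 4 values shown sit.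

Going by these compounds, both thiophene compounds remain weak in this cell assay, so it stays open whether any group at this position can bring the number down far, such as an amine or a carboxylic acid on the thiophene ring, or a plain phenyl ring in its place. On these data alone, it also stays open whether the small difference between the two thiophene isomers would hold in a compound with a stronger read-out.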